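Trading a Methoxy for a Hydroxypropyl on the Amide Nitrogen

The compounds below may be only part of what the source reports. "The series", "measured", "known", "first", "only" and "open" are said of these compounds alone.

Of the compounds shown here, three built around one shared core have been tested for their ability to switch on a cold-sensing ion channel in an assay on HEK293 cells for agonist activity at transient receptor potential cation channel subfamily M member 8 (Homo sapiens), read by fluorescence and calcium flux, with a stated time of 15 min; a lower number here means that less compound is needed, a higher number that more compound is needed for the effect. Compound 2 `CON(Cc1cccs1)C(=O)COc1ccc(C)cc1` gives 10 nM, the lowest number of the three. Compound 1 `CCN(Cc1cccs1)C(=O)COc1ccc(C(F)(F)F)cc1`, which carries a trifluoromethyl on the aryl ring and an ethyl on the amide nitrogen, gives 236 nM, and compound 3 `CCN(Cc1cccn1C)C(=O)COc1ccc(C)cc1`, with a methylated pyrrole in place of the thiophene, gives 21300 nM; both lie well beyond the scatter from compound 2.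

The next compound, compound 4 `Cc1ccc(OCC(=O)N(CCCO)Cc2cccs2)cc1`, keeps everything of compound 2 except one group: 3-hydroxypropyl in place of methoxy on an amide-type nitrogen. Among the measured compounds shown here, no measured pair differs in this place alone, so the size of the change cannot be read off the data. Since compound 2 is the lowest point reached and the methoxy is lost, a rise beyond the scatter is expected, and compound 4 is estimated at 120 nM, within 20 nM to 1000 nM. That would mean a step of a 12-fold higher number from compound 2 to compound 4 (1.08 log units; beyond the scatter), expected rather than known.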

Compound 4, half-maximal effective concentration: 3000 nM
Compound 4: middle estimate off by 25-fold (1.40 log units), on the low side, outside the stated range (above it).
By their numbers in this assay, from the lowest: compound 2; then compound 1; then compound 4; then compound 3.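

In this assay, putting 3-hydroxypropyl in place of methoxy on the amide-type nitrogen gives a 300-fold higher number from compound 2 to compound 4 (2.48 log units; beyond the scatter). Among the compounds shown here, this is the first step here that changes one place with the rest of the molecule held fixed, and it shows that the group on this nitrogen can by itself move the number by a large amount. The entering chain is larger than methoxy and brings a hydrogen-bond donor that methoxy lacks, but no measurement available here shows which of these differences, if either, accounts for the step.

The compounds shown leave open whether the chain or its hydroxyl matters more: a plain propyl or a 3-methoxypropyl on this nitrogen would help separate the two. From the compounds shown here alone, how an ethyl would read with the rest of compound 2 unchanged also remains open.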